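A few compounds are considered here, and "the series" means these few. Any claim that something is new, unique, unknown or untested is made for them only; others in the source may bear on it.

Measured compounds and values:

- compound 1, `COCc1ncc2cnnc(S)n12`: > 48000 nM
- compound 2, `Cc1ncc2cnnc(O)n12`: > 48000 nM
- compound 3, `C=CCSc1nncc2cnc(COC)n12`: 79000 nM

Among the compounds with values here, in a functional assay for inhibition, with Homo sapiens as the target (a lower number here means a stronger inhibitor, a higher number a weaker inhibitor), compound 3 gives 79000 nM, the only plain number among the three. The value of compound 1 in this assay, > 48000 nM, is a limit of the assay and not a number. The value of compound 2, > 48000 nM, is likewise a limit. Within the data shown here, because of the limit of > 48000 nM in this assay, at which 2 of the 3 values shown sit, the one measured step, a step that the limit leaves unreadable from compound 1 to compound 3, cannot be sized.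

Compound 4, `COCc1ncc2cnnc(O)n12`, is not yet measured. It differs from compound 3 by hydroxy in place of allylsulfanyl on an aromatic carbon. Compound 1 carries sulfur without the allyl and sits at the limit; compound 2 carries hydroxy at the same place and also sits at the limit, though its other substituent differs. Among the measured compounds shown here, with compound 3 itself weak, no measured step points to a gain, so compound 4 is expected to stay weak, most likely at the limit again; the step of a 1.0-fold higher number from compound 3 to compound 4 (0.01 log units; within the scatter) is the estimated change. The estimate for compound 4 is 80000 nM, expected between 30000 nM and 300000 nM.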

Compound 4, half-maximal inhibitory concentration: > 48000 nM
Compound 4 was reported as a limit (the forecaster's own chance of this, stated with the estimate: 70%); the middle value lies beyond the limit too.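

The steps linking compound 4 to compound 1, compound 2 and compound 3 cannot be read, because compound 4 is reported only as a limit and not as a number: the limit of > 48000 nM in this assay, at which 3 of the 4 values shown sit. The compounds shown leave open whether replacing allylsulfanyl with hydroxy changes inhibition at all.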